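From Compound 2 to Compound 3: A New Nitrogen Substituent

A few compounds are considered here, and "the series" means these few. Any claim that something is new, unique, unknown or untested is made for them only; others in the source may bear on it.

Within the data shown here, in a functional assay on K562 cells (Homo sapiens) for cytotoxicity, read by trypan blue exclusion, with a stated time of 96 h (a higher number here means a weaker inhibitor, a lower number a stronger inhibitor), compound 2 `COC(=O)C(C)(C)Nc1cc(CS(=O)(=O)/C=C/c2c(OC)cc(OC)cc2OC)ccc1OC` gives 800 nM, the higher of the two numbers so far, while compound 1 `COC(=O)C(F)(F)Nc1cc(CS(=O)(=O)/C=C/c2c(OC)cc(OC)cc2OC)ccc1OC` gives 250 nM. Compound 3 `COC(=O)C(Nc1cc(CS(=O)(=O)/C=C/c2c(OC)cc(OC)cc2OC)ccc1OC)c1ccccc1` carries methoxycarbonyl)(benzyl in place of 1-(methoxycarbonyl)-1-methylethyl on a nitrogen on an aromatic ring. Among the measured compounds shown here, one measured step bears on this change, since it altered the group at that same nitrogen: a 3.2-fold higher number from compound 1 to compound 2 (0.51 log units; beyond the scatter). With so little data, a similarly modest move toward a lower number in this assay is expected, a 2.3-fold lower number from compound 2 to compound 3 (0.36 log units; beyond the scatter). For compound 3, the estimated value is 350 nM, with an expected range of 90 nM to 1300 nM.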

Compound 3, half-maximal inhibitory concentration: 30 nM
Beside the measured number, compound 3's estimate is 12-fold (1.07 log units) above it; the whole stated range lies above it.
By their numbers in this assay, from the lowest: compound 3; then compound 1; then compound 2.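

In this assay, the group on this nitrogen can shift the number much further than the first pair showed. Bringing in a six-membered aromatic ring gives a 27-fold lower number from compound 2 to compound 3 (1.43 log units; beyond the scatter), and the same ring also gives an 8.3-fold lower number from compound 1 to compound 3 (0.92 log units; beyond the scatter) against the difluoro group, so compound 3 has the lowest number of the three. Nothing measured here gives a reason for this gain.

Whether the aromatic ring itself accounts for the change remains open. So does how a pyridine ring, a longer chain ending in a phenyl ring, or a carboxylic acid in place of the methyl ester would behave on this nitrogen.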